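Removing the Thiazole Ester: Compound 3 to Compound 4

This account rests on a few compounds, and the source may have more. Where it says the series, first, only, none or still open, it means among the compounds named here.

Measured compounds:
compound 1, `COC(=O)c1ccc(-c2cn(CC(=O)Nc3nc(C)cs3)nn2)cc1`, > 30000 nM
compound 2, `Cc1cc(NC(=O)Cn2cc(-c3ccc([N+](=O)[O-])cc3)nn2)no1`, 1220 nM
compound 3, `CCOC(=O)c1sc(NC(=O)Cn2cc(-c3ccc([N+](=O)[O-])cc3)nn2)nc1C`, 1840 nM

All three compounds were tested in a functional assay on BMDM cells (Mus musculus, strain C57BL/6) for inhibition, with a stated time of 2 days; a higher number here means a weaker inhibitor, a lower number a stronger inhibitor. Compound 1 gives > 30000 nM, which is a limit of the assay rather than a number. Compound 2 gives 1220 nM. Compound 3 gives 1840 nM; among the two numbers recorded, this is the higher one, but its distance from compound 2 lies within the usual scatter, so the two cannot be ranked against each other.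

The not yet measured compound 4, `Cc1csc(NC(=O)Cn2cc(-c3ccc([N+](=O)[O-])cc3)nn2)n1`, is obtained from compound 3 by the change (hydrogen in place of ethoxycarbonyl on an aromatic carbon). The shared core of compounds 2, 3 and 4 carries the nitrophenyl group, whereas compound 1 carries a methyl ester on the phenyl ring instead and sits at the limit (the limit of > 30000 nM in this assay, at which 1 of the 3 values shown sits).

Going by the values given here, no measured pair differs in exactly this place, so the size of the step is uncertain. Because compound 2 gives 1220 nM and compound 3 gives 1840 nM that sit within the scatter of each other, the expectation is that trimming the ethoxycarbonyl will not move the value far, with the step from compound 3 to compound 4 expected to be a 1.4-fold lower number from compound 3 to compound 4 (0.15 log units; within the scatter), essentially none beyond the scatter. Compound 4 is estimated at 1300 nM, with a plausible range from 400 nM to 4500 nM.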

Compound 4, half-maximal inhibitory concentration: 190 nM
For compound 4 the middle estimate is 6.8-fold (0.84 log units) above the measured one; measured number outside the range, below it.
By their numbers in this assay, from the lowest: compound 4; then compounds 2 and 3 (each within the scatter of the next). At a limit, above all of these: compound 1.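

In this assay, going by these compounds alone, replacing the ethoxycarbonyl with hydrogen, on the aromatic carbon next to the ring sulfur and next to the ring atom that bears a methyl group, gives a 9.7-fold lower number from compound 3 to compound 4 (0.99 log units; beyond the scatter), which shows that the ethoxycarbonyl is not required at this position and that the lower number comes with the bare ring carbon, something the earlier compounds gave no sign of. With that group gone, the amide-type nitrogen substituent also separates, as 4-methyl-1,3-thiazol-2-yl in place of 5-methyl-1,2-oxazol-3-yl gives a 6.4-fold lower number from compound 2 to compound 4 (0.81 log units; beyond the scatter), a difference that the values of compound 2 and compound 3, within the scatter of each other, did not reveal. On the phenyl ring, nitro in place of methoxycarbonyl gives an at least 150-fold lower number from compound 1 to compound 4 (2.19 log units; beyond the scatter), a step that rests on a limit of the assay for compound 1 and not on a number: the limit of > 30000 nM in this assay, at which 1 of the 4 values shown sits.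

The compounds shown leave open whether a small group other than hydrogen, such as a carboxylic acid or a primary amide, would hold the number of compound 4 at this position. They also do not tell what the neighbouring methyl contributes, or whether an amine could stand in place of the nitro.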